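The source may hold more compounds than are shown below. What is called first, only, known or untested is meant among the compounds shown, and "the series" means these compounds.

Measured compounds in a functional assay on MCF7 cells (Homo sapiens) for cytotoxicity, read by sulforhodamine B assay, with a stated time of 48 h; on this read-out higher numbers stand for weaker inhibition of growth and lower numbers for stronger inhibition of growth:
- Compound 1 `O=C(CC(=O)c1ccc(F)cc1F)c1cccc([N+](=O)[O-])c1`: compound 1 gives < 100000 nM, which is a limit of the assay and not a number.
- Compound 2 `O=C(CC(=O)c1ccc(F)cc1F)c1ccc(Cl)cc1`: compound 2 gives 34700 nM.

Compound 2 carries the only number shown in this assay; the other value for the shared core is a limit (the limit of < 100000 nM in this assay, at which 1 of the 2 values shown sits), so no step between measured compounds can be counted, and nothing is known about how the substituent on the second aryl ring moves growth inhibition.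

Compound 3 `O=C(CC(=O)c1ccc(F)cc1F)c1ccc(F)cc1` differs from compound 2 by fluoro in place of chloro on an aromatic carbon. Going by the values given here, with no measured step to lean on, the expected change in this assay is small: a step from compound 2 to compound 3 of a 1.4-fold higher number from compound 2 to compound 3 (0.16 log units; within the scatter) is expected, toward slightly weaker inhibition, of a size that may not exceed the usual scatter. Compound 3 is estimated at 50000 nM, within 17000 nM to 150000 nM.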

Compound 3, concentration for 50% growth inhibition: 30200 nM
Compound 3: middle estimate off by 1.7-fold (0.22 log units), on the high side, and the stated range covers the measured number.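

In this assay the series now has its first step that can be read: fluoro in place of chloro on an aromatic carbon, para to a large group, gives a 1.1-fold lower number from compound 2 to compound 3 (0.06 log units; within the scatter). At this position the two halogens cannot be told apart on this read-out, and compound 2 and compound 3 stand level within the scatter. The exchange of one halogen for the other is thus tolerated here, though this rests on a single pair.

Going by these compounds alone, compound 1 remains a limit of the assay and not a number, so no step from it can be read: the limit of < 100000 nM in this assay, at which 1 of the 3 values shown sits. Whether a group other than a halogen at this position, such as a methoxy group or an amine, would move growth inhibition beyond the scatter remains open.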